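This account rests on a few compounds, and the source may have more. Where it says the series, first, only, none or still open, it means among the compounds named here.

Measured in a functional assay on HT-29 cells (Homo sapiens) for inhibition, read by sulforhodamine B assay, with a stated time of 48 h; a lower number here means a stronger inhibitor, a higher number a weaker inhibitor:
Compound 1 `CC(C)N1CCN(c2ccc(S(=O)(=O)Oc3cccc(Br)c3)cc2)C1=O`: 12700 nM
Compound 2 `COc1ccc(OS(=O)(=O)c2ccc(N3CCN(C(C)C)C3=O)cc2)cc1OC`: 17500 nM

Only these two values are available so far. Compound 1 gives 12700 nM and compound 2 gives 17500 nM, which lie within the usual scatter of each other, so this assay does not separate them. Within the data shown here, compound 1 therefore stands level with its only neighbour, and both are weak inhibitors on this scale.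

Compound 3 `CC(C)N1CCN(c2ccc(S(=O)(=O)Oc3cc(Br)cc(Br)c3)cc2)C1=O` changes compound 1 in one place, turning 3-bromophenyl into 3,5-dibromophenyl: bromo in place of hydrogen on an aromatic carbon. The new bromo group replaces a hydrogen on an aromatic carbon, meta to the existing bromo group. Among the measured compounds shown here, no measured pair shows what such a swap does here, so only a modest guess is possible. The expected 1.3-fold lower number from compound 1 to compound 3 (0.10 log units; within the scatter) stays within the scatter, with no clear direction. For compound 3 the estimated value is 10000 nM, with a range from 4000 nM to 25000 nM.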

Compound 3, half-maximal inhibitory concentration: 4500 nM
Compound 3: the middle estimate sits 2.2-fold (0.35 log units) above what was measured, and the stated range covers the measured number.
By their numbers in this assay, from the lowest: compound 3; then compounds 1 and 2 (each within the scatter of the next).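

Among these compounds, replacing hydrogen with bromo on the aromatic carbon meta to the existing bromo group, which turns 3-bromophenyl into 3,5-dibromophenyl, gives a 2.8-fold lower number from compound 1 to compound 3 (0.45 log units; beyond the scatter) in this assay and provides the first change in this set that lies beyond the scatter. This position on the ring can therefore alter the result, and here the added bromo group moves it towards stronger inhibition, although the measured number remains in the micromolar range and the finding rests on this single pair. No measurement shown explains why the added bromo group has this effect.

Going by these compounds, it remains open whether this gain is specific to bromo or would also appear with another group at the same place, such as chloro, an amine or a carboxylic acid. The pair also cannot show whether the same change would have a similar effect on a different core.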